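Replacing cyano with bromo on the shared core

The source may report more compounds than this note shows. Statements on the series, on what has been measured and on what is new or still open speak of the compounds shown alone.

In a functional assay on DLD-1 cells (Homo sapiens) for cytotoxicity, with a stated time of 48 h (a lower number here means a stronger inhibitor, a higher number a weaker inhibitor), compound 3 `C[S+]([O-])/C=C/c1cc(=O)c2cc(C#N)ccc2o1` gives > 10000 nM, which is a limit and not a number. It stands at the limit of > 10000 nM in this assay, at which 1 of the 3 values shown sits. Compound 1 `CCOc1ccc2oc(/C=C/[S+](C)[O-])cc(=O)c2c1` gives 4900 nM and compound 2 `CCCCCOc1ccc2oc(/C=C/[S+](C)[O-])cc(=O)c2c1` gives 6600 nM, with a 1.3-fold higher number from compound 1 to compound 2 (0.13 log units; within the scatter). Compound 4 `C[S+]([O-])/C=C/c1cc(=O)c2cc(Br)ccc2o1` has bromo in place of cyano on an aromatic carbon, (bromo in place of cyano on an aromatic carbon). Within the data shown here, two measured steps bear on this change, an at least 2.0-fold higher number from compound 1 to compound 3 (0.30 log units; that floor lies within the scatter) and an at least 1.5-fold higher number from compound 2 to compound 3 (0.18 log units; that floor lies within the scatter), and each gives only a floor. A modest move toward a lower number is therefore expected in this assay, with the estimated step being an at least 1.4-fold lower number from compound 3 to compound 4 (0.15 log units; that floor lies within the scatter). The estimate for compound 4 is 7000 nM, with an expected range of 3000 nM to 15000 nM.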

Compound 4, half-maximal inhibitory concentration: 4500 nM
Beside the measured number, compound 4's estimate is 1.6-fold (0.19 log units) above it; the measured number falls inside the stated range.
By their numbers in this assay, from the lowest: compounds 4, 1 and 2 (each within the scatter of the next). At a limit, above all of these: compound 3.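

In this assay, bromo in place of cyano on this aromatic carbon gives an at least 2.2-fold lower number from compound 3 to compound 4 (0.34 log units; beyond the scatter), the first step at this position to clear the scatter, though its size is only a floor: the limit of > 10000 nM in this assay, at which 1 of the 4 values shown sits.

Bromo in place of ethoxy gives a 1.1-fold lower number from compound 1 to compound 4 (0.04 log units; within the scatter), and bromo in place of pentyloxy gives a 1.5-fold lower number from compound 2 to compound 4 (0.17 log units; within the scatter), so compound 1, compound 2 and compound 4 cannot be told apart.

Going by these compounds, how far compound 3 truly lies from the others stays open. So does whether an amine or a carboxylic acid on this carbon would give a number clearly apart from compound 4.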